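The source may report more compounds than this note shows. Statements on the series, on what has been measured and on what is new or still open speak of the compounds shown alone.

Measured so far:
Compound 1 `C[C@@H](NC(=O)c1ccc(C#Cc2ccccc2)cn1)C(C)(C)O`: 60.9%
Compound 2 `C[C@@H](NC(=O)c1ccc(C#Cc2cc(F)cc(F)c2)cn1)C(C)(C)O`: 61.6%

In a functional assay on HEK293 cells for positive allosteric modulation of metabotropic glutamate receptor 5 (Rattus norvegicus), read by fluorescence and calcium flux (on this read-out lower numbers stand for smaller maximal responses and higher numbers for larger maximal responses), compound 1 gives 60.9% and compound 2 gives 61.6%. Among the compounds with values here, the only change between them, 3,5-difluorophenyl in place of phenyl on a triple-bonded carbon, brought a number 0.7 percentage points higher from compound 1 to compound 2 (within the scatter). Compound 2 thus holds the highest of the two numbers, yet its nearest neighbour, compound 1, lies within the scatter of it, so no order can be read between them. Compound 3 `C[C@@H](NC(=O)c1ccc(C#Cc2ccc(F)cc2F)cn1)C(C)(C)O` keeps the same atoms as compound 2 but joins them differently: 2,4-difluorophenyl in place of 3,5-difluorophenyl on a triple-bonded carbon. Within the data shown here, the one step that bears on this change is the earlier move from phenyl to 3,5-difluorophenyl, which stayed within the scatter. Because a number 0.7 percentage points higher from compound 1 to compound 2 (within the scatter) shifted the maximal response so little, the expectation for 2,4-difluorophenyl in place of 3,5-difluorophenyl is no step beyond the scatter in this assay. For compound 3 the estimate is 61%, with a range from 49% to 73%. That estimate means an expected step of a number 0.6 percentage points lower from compound 2 to compound 3 (within the scatter).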

Compound 3, largest response reached (reported as efficacy), in percent of the reference or control that the assay uses: 61.2%
For compound 3 the middle estimate is 0.2 percentage points below the measured one; the range from low to high includes it.
By their numbers in this assay, from the lowest: compounds 1, 3 and 2 (each within the scatter of the next).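

Moving the two fluorines on the ring, with 2,4-difluorophenyl in place of 3,5-difluorophenyl on a triple-bonded carbon, gives a number 0.4 percentage points lower from compound 2 to compound 3 (within the scatter) in this assay for this change. Measured against the plain phenyl, the new ring gives a number 0.3 percentage points higher from compound 1 to compound 3 (within the scatter) in this assay as well, so at this position neither the presence of the two fluorines nor their arrangement on the ring separates these three compounds. Nothing in the data available explains why the maximal response stays so flat here.

The compounds shown leave open whether any group on this ring can move the maximal response beyond the scatter, for example a methoxy group or a nitrile. From the compounds shown here alone, whether a larger change, such as a pyridine ring in place of the phenyl, would do so also remains open.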